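Swapping 1-benzofuran-2-yl for ethynyl on the shared core

The source may report more compounds than this note shows. Statements on the series, on what has been measured and on what is new or still open speak of the compounds shown alone.

In a functional assay on CCRF-CEM cells (Homo sapiens), read by MTT assay, with a stated time of 72 h (a lower number here means a stronger inhibitor, a higher number a weaker inhibitor), compound 1 `C#Cc1cn([C@@H]2O[C@H](CO)[C@@H](O)[C@H]2O)c2ncnc(N(C)C)c12` gives 90 nM and compound 2 `Cc1ncnc2c1c(-c1cc3ccccc3o1)cn2[C@@H]1O[C@H](CO)[C@@H](O)[C@H]1O` gives 17300 nM. Compound 2 therefore holds the higher of the two numbers and is the weaker inhibitor of the pair, with a gap beyond the scatter. The next compound to test is compound 3 `C#Cc1cn([C@@H]2O[C@H](CO)[C@@H](O)[C@H]2O)c2ncnc(C)c12`, which has ethynyl in place of 1-benzofuran-2-yl on an aromatic carbon. Going by the values given here, no measured step between two compounds isolates this change. Among the compounds with values here, the only guide is compound 1, which also carries ethynyl at that place and gives 90 nM in this assay, though it differs from compound 3 elsewhere. A large drop in the number, beyond the scatter, is therefore expected, with an estimated 58-fold lower number from compound 2 to compound 3 (1.76 log units; beyond the scatter). Compound 3 is expected at 300 nM, with an estimated range of 50 nM to 2000 nM.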

Compound 3, half-maximal inhibitory concentration: 5600 nM
Compound 3: middle estimate off by 19-fold (1.27 log units), on the low side; the whole stated range lies below it.
By their numbers in this assay, from the lowest: compound 1; then compound 3; then compound 2.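

In this assay, with methyl held constant on the shared core, ethynyl in place of 1-benzofuran-2-yl gives a 3.1-fold lower number from compound 2 to compound 3 (0.49 log units; beyond the scatter), so this change is a real but modest gain at this position. The larger step lies at the other place: methyl in place of dimethylamino gives a 62-fold higher number from compound 1 to compound 3 (1.79 log units; beyond the scatter) with ethynyl unchanged, so the low number of compound 1 cannot be credited to ethynyl alone. No measurement at hand gives a cause for either step.

From the compounds shown here alone, it remains open whether a nitrile or a bromine atom in place of ethynyl would give a lower number than ethynyl does with methyl on the core. Going by these compounds, it is also open whether an unsubstituted amino or a methoxy group in place of dimethylamino would keep the number near that of compound 1 90 nM in this series.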